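Carbamate in place of a pyrrolidinylmethyl amine

A few compounds are considered here, and "the series" means these few. Any claim that something is new, unique, unknown or untested is made for them only; others in the source may bear on it.

Two compounds have been measured in an assay on HEK293 cells for displacement of a labelled ligand from Melanocortin receptor 4 (Homo sapiens); a lower number here means a stronger inhibitor, a higher number a weaker inhibitor:
compound 1, `CCC(C)[C@H](NCCN)c1cc(C(F)(F)F)ccc1N1CCN(C(=O)CCc2ccc(Cl)cc2Cl)CC1`, gives 56 nM
compound 2, `CCC(C)[C@H](NC[C@H]1CCCN1)c1cc(C(F)(F)F)ccc1N1CCN(C(=O)CCc2ccc(Cl)cc2Cl)CC1`, gives 110 nM

Compound 2 stands at the higher of the two numbers, and its nearest neighbour is compound 1, though the step of a 2.0-fold higher number from compound 1 to compound 2 (0.29 log units; within the scatter) lies within the scatter, so the two cannot be ordered.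

Compound 3, `CCC(C)[C@H](NC(=O)OC)c1cc(C(F)(F)F)ccc1N1CCN(C(=O)CCc2ccc(Cl)cc2Cl)CC1`, is not yet measured. It differs from compound 2 in one place: methoxycarbonyl in place of (pyrrolidin-2-yl)methyl on an amine nitrogen. Going by the values given here, the only measured step, a 2.0-fold higher number from compound 1 to compound 2 (0.29 log units; within the scatter), exchanges one amine-bearing group for another and leaves the amine nitrogen as a hydrogen-bond donor; it therefore bears only loosely on the present change, in which the donor on that nitrogen is lost and two acceptors enter. Among the compounds with values here, no measured pair shows what happens in this assay when that donor is removed.

Within the data shown here, with no direct precedent, the expectation for compound 3 rests on the size of the change alone. A weakening step a 4.1-fold higher number from compound 2 to compound 3 (0.61 log units; beyond the scatter) is expected, with a wide range. The estimate for compound 3 in this assay is 450 nM, between 100 nM and 2500 nM.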

Compound 3, inhibition constant: 2400 nM
Beside the measured number, compound 3's estimate is 5.3-fold (0.73 log units) below it; the range from low to high includes it.
By their numbers in this assay, from the lowest: compounds 1 and 2 (each within the scatter of the next); then compound 3.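

In this assay, going by these compounds alone, the amine nitrogen had so far carried only two amine-bearing groups, 2-aminoethyl and (pyrrolidin-2-yl)methyl, and the exchange between them stayed within the scatter. Methoxycarbonyl on that nitrogen is the first change to move the number substantially, with a 22-fold higher number from compound 2 to compound 3 (1.34 log units; beyond the scatter) and a 43-fold higher number from compound 1 to compound 3 (1.63 log units; beyond the scatter), so this position does not treat all groups alike: the two amine-bearing groups stay together, while the methoxycarbonyl compound stands well apart from both. Nothing measured here accounts for the size of these steps.

The compounds shown leave open which part of the exchange matters, since the amine of the departing group goes and a carbonyl arrives in the same step. An ethyl group on that nitrogen would test the removal of the amine without adding a carbonyl, while a 3-aminopropyl chain would show how far the amine-bearing groups can be extended at this position, and an acetyl group would show whether the methoxy oxygen plays any part.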